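A New Aryl Group on the Amine Nitrogen

The source may hold more compounds than are shown below. What is called first, only, known or untested is meant among the compounds shown, and "the series" means these compounds.

Measured so far in a physicochemical assay, read by spectrophotometry; on this read-out lower numbers stand for stronger inhibition and higher numbers for weaker inhibition:
- compound 1 `CN(C)c1ccc(/C=C/C(=O)/C=C(O)/C=C/c2ccc(N(C)C)cc2)cc1` gives 78.5 ug/mL
- compound 2 `CN(C)c1ccc(/C=C/C(=O)/C(CNc2ccc(F)cc2)=C(O)/C=C/c2ccc(N(C)C)cc2)cc1` gives 48.2 ug/mL
- compound 3 `CN(C)c1ccc(/C=C/C(=O)/C(CNc2cccc(C(F)(F)F)c2)=C(O)/C=C/c2ccc(N(C)C)cc2)cc1` gives 81.7 ug/mL

Compound 2 stands level with the other two, since its value lies within the usual scatter of both compound 1 and compound 3. These numbers therefore cannot rank the three compounds.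

Compound 4 `COc1ccccc1NC/C(C(=O)/C=C/c1ccc(N(C)C)cc1)=C(O)\C=C\c1ccc(N(C)C)cc1` has not yet been measured. It carries 2-methoxyphenyl in place of 4-fluorophenyl on an amine nitrogen. Going by the values given here, only one measured change bears on this place. Putting 3-(trifluoromethyl)phenyl in place of 4-fluorophenyl gives a 1.7-fold higher number from compound 2 to compound 3 (0.23 log units; within the scatter) and that stays within the scatter. Among the compounds with values here, one step is thin evidence, and no measured compound carries 2-methoxyphenyl. Even so, nothing here points to a real shift in this assay in either direction. The estimated change, a 1.3-fold higher number from compound 2 to compound 4 (0.11 log units; within the scatter), is expected to stay within the scatter. Compound 4 is expected to read 62 ug/mL with an estimated range from 35 ug/mL to 110 ug/mL in this measurement.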

Compound 4, half-maximal inhibitory concentration: 76.3 ug/mL
Beside the measured number, compound 4's estimate is 1.2-fold (0.09 log units) below it; the range from low to high includes it.
By their numbers in this assay, from the lowest: compounds 2, 4, 1 and 3 (each within the scatter of the next).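

In this assay, a third aryl group on the amine nitrogen, 2-methoxyphenyl, brings an oxygen and a hydrogen-bond acceptor that 4-fluorophenyl lacks, yet the exchange gives a 1.6-fold higher number from compound 2 to compound 4 (0.20 log units; within the scatter) and no real shift can be read from it. Against 3-(trifluoromethyl)phenyl, the same group gives a 1.1-fold lower number from compound 3 to compound 4 (0.03 log units; within the scatter) and again stays within the usual variation between repeats. The second measured comparison at this nitrogen therefore leaves compounds 2, 3 and 4 unranked, now across three different aryl groups. Nothing available here speaks to the reason for this result.

All the groups shown on this nitrogen are substituted phenyl rings. Going by these compounds, whether a carboxylic acid on the ring, or a longer carbon chain in place of the ring, would move the number beyond the scatter remains open.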